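A few compounds are considered here, and "the series" means these few. Any claim that something is new, unique, unknown or untested is made for them only; others in the source may bear on it.

Working notes on the series. The shared core of compound 1 `CC1=CC[C@H](C(C)(C)NC(=S)N/N=C/c2ccccc2)CC1` carries a benzylidene group on the thiosemicarbazide; in a functional assay on UACC-62 cells (Homo sapiens) for inhibition, read by sulforhodamine B assay, with a stated time of 48 h (on this read-out lower numbers stand for stronger inhibition of growth and higher numbers for weaker inhibition of growth), compound 1 gives 31600 nM. Compound 2 `CC1=CC[C@H](C(C)(C)NC(=S)N/N=C/c2ccc(N(C)C)cc2)CC1` has dimethylamino in place of hydrogen on an aromatic carbon, and in this assay compound 2 gives 45100 nM. Compound 2 thus stands highest of the two numbers measured, with compound 1 nearest; the step of a 1.4-fold higher number from compound 1 to compound 2 (0.15 log units; within the scatter) lies within the scatter, so no order between the two can be claimed. Compound 3 `CC1=CC[C@H](C(C)(C)NC(=S)N/N=C/c2ccc(F)cc2)CC1` is not yet measured. It differs from compound 2 as follows: fluoro in place of dimethylamino on an aromatic carbon; the fluoro sits on an aromatic carbon of a six-membered aromatic ring of carbon only, para to a large group. Going by the values given here, only the step of a 1.4-fold higher number from compound 1 to compound 2 (0.15 log units; within the scatter) bears on substitution at this position, and it shows no effect beyond the scatter; no measured step covers fluoro itself. The expectation in this assay is therefore a step of a 1.3-fold lower number from compound 2 to compound 3 (0.11 log units; within the scatter), that is, nothing beyond the scatter. Compound 3 is estimated at 35000 nM, with a range of 14000 nM to 90000 nM.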

Compound 3, concentration for 50% growth inhibition: > 100000 nM
Compound 3 was reported as a limit (the forecaster's own chance of this, stated with the estimate: 10%); middle value at least 2.8-fold (0.45 log units) away from the limit.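

In this assay the result for compound 3 is a limit of the assay and not a number: the limit of > 100000 nM in this assay, at which 1 of the 3 values shown sits.

The position on the aromatic ring is not indifferent to what it carries. Dimethylamino and hydrogen give no separable order, with a 1.4-fold higher number from compound 1 to compound 2 (0.15 log units; within the scatter), whereas fluoro moves the read-out clearly towards weaker inhibition of growth, with an at least 2.2-fold higher number from compound 2 to compound 3 (0.34 log units; beyond the scatter) and an at least 3.1-fold higher number from compound 1 to compound 3 (0.50 log units; beyond the scatter). Of the three groups shown at this place, fluoro alone gives a step beyond the scatter, so a single-atom replacement on this aromatic carbon is enough to separate compounds in this series, and both steps give only a lower bound on the size of the change.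

The compounds shown leave open whether chloro, bromo or methoxy at the same place would go with fluoro or stay with hydrogen and dimethylamino, and so whether the step belongs to fluoro alone or to a wider set of groups. They also leave open whether fluoro on another aromatic carbon of the ring, or a nitrile or a carboxylic acid in its place, would give a step of similar size.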